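Swapping a Thiophene for a Furan on Two Related Cores

The source may hold more compounds than are shown below. What is called first, only, known or untested is meant among the compounds shown, and "the series" means these compounds.

Compound 1 `Cc1nc(N)c2c(-c3cccs3)cn([C@@H]3O[C@H](CO)[C@@H](O)[C@H]3O)c2n1` and compound 2 `Nc1nc2c(c(-c3cccs3)cn2[C@@H]2O[C@H](CO)[C@@H](O)[C@H]2O)c(=O)[nH]1` both carry a sugar on a fused two-ring system and a thiophen-2-yl group; the difference between their two cores is not broken down here. Compound 3 `Cc1nc(N)c2c(-c3ccoc3)cn([C@@H]3O[C@H](CO)[C@@H](O)[C@H]3O)c2n1` derives from compound 1 by the change (furan-3-yl in place of thiophen-2-yl on an aromatic carbon). Compound 4 `Nc1nc2c(c(-c3ccoc3)cn2[C@@H]2O[C@H](CO)[C@@H](O)[C@H]2O)c(=O)[nH]1` has not been measured; it derives from compound 2 by the change (furan-3-yl in place of thiophen-2-yl on an aromatic carbon), made at the same place as in compound 3, so it is the same change on the other core.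

In a functional assay on HepG2 cells (Homo sapiens) for antiproliferative activity, read by XTT assay, with a stated time of 72 h (on this read-out lower numbers stand for stronger inhibition and higher numbers for weaker inhibition), compound 1 gives only a limit, > 20000 nM. In this assay compound 2 also gives only a limit, > 20000 nM. Compound 3 returns a limit as well, > 20000 nM. As a result the step that the two limits leave unreadable from compound 1 to compound 3 cannot be read, since both of its ends sit at the limit of > 20000 nM in this assay, at which 3 of the 3 values shown sit.

For compound 4 the expected step that the limit leaves unreadable from compound 2 to compound 4 is therefore essentially nothing that can be resolved, resting on the observation that the same change from compound 1 to compound 3 moved nothing off (the limit of > 20000 nM in this assay, at which 3 of the 3 values shown sit). Compound 4 is thus expected to come out near 30000 nM, most likely reported again only as a limit, with an expected range from 15000 nM to 100000 nM.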

Compound 4, half-maximal inhibitory concentration: > 20000 nM
Compound 4 ended at the assay's limit (the forecaster's own chance of this, stated with the estimate: 90%); the middle value lies beyond the limit too.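

In this assay compound 4 gives > 20000 nM, which is a limit and not a number. Compound 2 also gives only a limit, so the step from compound 2 to compound 4 cannot be read, just as the one from compound 1 to compound 3 cannot: the limit of > 20000 nM in this assay, at which 4 of the 4 values shown sit.

The compounds shown leave open whether thiophen-2-yl and furan-3-yl, or the two cores, differ at all in this assay.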